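Removing the Bromine from a Hydroxyphenyl Hydrazone

The source may report more compounds than this note shows. Statements on the series, on what has been measured and on what is new or still open speak of the compounds shown alone.

Two measured compounds share one core and differ only in the aromatic ring attached to the carbon that carries a double bond to nitrogen. Compound 1 `O=C(CSc1nnc(-c2ccncc2)n1-c1ccccc1)N/N=C/c1ccc(Br)cc1` carries a 4-bromophenyl there; in a functional assay on HCT-116 cells (Homo sapiens) for inhibition, read by MTT assay, with a stated time of 48 h (on this read-out higher numbers stand for weaker inhibition and lower numbers for stronger inhibition), compound 1 gives 4500 nM. Compound 2 `O=C(CSc1nnc(-c2ccncc2)n1-c1ccccc1)N/N=C/c1cc(Br)ccc1O` carries a 5-bromo-2-hydroxyphenyl instead, and in this assay compound 2 gives 1990 nM. That single swap produced a 2.3-fold lower number from compound 1 to compound 2 (0.35 log units; beyond the scatter). Of the two numbers available, compound 2 has the lower one, which on this read-out means stronger inhibition, with compound 1 a modest step above it.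

Compound 3 `O=C(CSc1nnc(-c2ccncc2)n1-c1ccccc1)N/N=C/c1ccccc1O` takes the next step: hydrogen in place of bromo on an aromatic carbon. Going by the values given here, no measured step isolates this change. Among the compounds with values here, the one step measured, from compound 1 to compound 2, relocated the bromine and introduced the hydroxy group at the same time, so it cannot show what the bromine alone contributes. In this assay the expected step is therefore a 1.5-fold higher number from compound 2 to compound 3 (0.18 log units; within the scatter), small and of uncertain direction, with a somewhat higher number judged slightly more likely. Compound 3 is accordingly estimated to give 3000 nM in this assay, with a plausible range from 1200 nM to 8000 nM.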

Compound 3, half-maximal inhibitory concentration: 7060 nM
For compound 3 the middle estimate is 2.4-fold (0.37 log units) below the measured one, within the range that was stated.
By their numbers in this assay, from the lowest: compound 2; then compounds 1 and 3 (each within the scatter of the next).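

In this assay, going by these compounds alone, removing the bromine alone gives a 3.5-fold higher number from compound 2 to compound 3 (0.55 log units; beyond the scatter) and so offers the first reading of the bromo group by itself: with a hydroxy group on the ring, hydrogen in place of bromo on the aromatic carbon para to that hydroxy group goes with weaker inhibition, a modest step beyond the scatter. The other new comparison, 2-hydroxyphenyl in place of 4-bromophenyl, gives a 1.6-fold higher number from compound 1 to compound 3 (0.20 log units; within the scatter) and lies within the scatter, so these two rings cannot be told apart here, and among these three compounds the stronger inhibition appears only where bromo and hydroxy stand together on the 5-bromo-2-hydroxyphenyl ring. No supporting measurement is available to explain either step.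

The compounds shown leave open whether bromine is needed on that carbon or whether a chlorine atom, a methyl group or a methoxy group would serve in the same way. They also leave open what the hydroxy group contributes alone, a question that a comparison between the 2-hydroxyphenyl ring and an unsubstituted phenyl ring could address.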